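The source may hold more compounds than are shown below. What is called first, only, known or untested is meant among the compounds shown, and "the series" means these compounds.

Measured in a functional assay on HT-29 cells (Homo sapiens) for inhibition, read by sulforhodamine B assay, with a stated time of 72 h; a higher number here means a weaker inhibitor, a lower number a stronger inhibitor:
compound 1 `C#Cc1cccc(Nc2ncnc3cc(OCCCCCn4ccnc4[N+](=O)[O-])c(OC)cc23)c1`: 1310 nM
compound 2 `COc1cc2c(Nc3cccc(Br)c3)ncnc2cc1OCCCCn1ccnc1[N+](=O)[O-]`: 4020 nM

Compound 2 has the higher number of the two, and its gap to compound 1 lies beyond the scatter. Compound 3 `COc1cc2c(Nc3cccc(Br)c3)ncnc2cc1OCCCCCn1ccnc1[N+](=O)[O-]` differs from compound 2 by one change: (2-nitro-1H-imidazol-1-yl)methyl in place of 2-nitro-1H-imidazol-1-yl on a saturated chain carbon, four bonds along the chain from an oxygen on an aromatic ring. Within the data shown here, no measured pair shows this change alone. Compound 1 at 1310 nM shares the chain of compound 3 but differs elsewhere, so a small step toward a lower number in this assay is expected, possibly within the scatter. The expected step is a 1.6-fold lower number from compound 2 to compound 3 (0.21 log units; within the scatter). Compound 3 is estimated at 2500 nM, with an expected range of 1000 nM to 6000 nM.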

Compound 3, half-maximal inhibitory concentration: 5050 nM
Estimate against measurement, compound 3: 2.0-fold (0.31 log units) below; low and high end bracket the measured number.
By their numbers in this assay, from the lowest: compound 1; then compounds 2 and 3 (each within the scatter of the next).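

In this assay the (2-nitro-1H-imidazol-1-yl)methyl group in place of 2-nitro-1H-imidazol-1-yl at this saturated chain carbon gives a 1.3-fold higher number from compound 2 to compound 3 (0.10 log units; within the scatter) and so separates this pair by no more than the scatter. Among these compounds, with the chain held constant, bromo in place of ethynyl on an aromatic carbon gives a 3.9-fold higher number from compound 1 to compound 3 (0.59 log units; beyond the scatter) and is the only step here beyond the scatter. No measured evidence bears on the reason for either step.

From the compounds shown here alone, whether a longer chain would behave the same way remains open. So does the outcome of replacing the 2-nitro-1H-imidazol-1-yl group with an amine or a carboxylic acid.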